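Chain shortening on two related amino-alcohol cores

The source may report more compounds than this note shows. Statements on the series, on what has been measured and on what is new or still open speak of the compounds shown alone.

In a functional assay on B16-F10 cells (Mus musculus) for antiproliferative activity, read by MTT assay, with a stated time of 72 h (on this read-out lower numbers stand for stronger inhibition and higher numbers for weaker inhibition), compound 1 `CCCCCCCCCCNC[C@@H]1OC[C@H](N)[C@@H]1O` gives 29600 nM. Compound 2 `CCCCCCCNC[C@@H]1OC[C@H](N)[C@@H]1O` reaches only a limit of this assay, > 128000 nM, which is the limit of > 128000 nM in this assay, at which 1 of the 3 values shown sits. The change is hydrogen in place of propyl on a saturated chain carbon, seven bonds along the chain from an amine nitrogen, and it reads as an at least 4.3-fold higher number from compound 1 to compound 2 (0.63 log units; beyond the scatter). Compound 3 `CCCCCCCCCCCNC[C@@H]1OC[C@H](N)[C@H]1O` is built on a core whose difference from that of compound 1 is not broken down here; in this assay compound 3 gives 88800 nM. Compound 4 `CCCCCCCCNC[C@@H]1OC[C@H](N)[C@H]1O` is not yet measured. It differs from compound 3 by hydrogen in place of propyl on a saturated chain carbon, eight bonds along the chain from an amine nitrogen, the same kind of change as before, though here eight bonds along the chain rather than seven. Resting on compound 3 at 88800 nM and on the step of an at least 4.3-fold higher number from compound 1 to compound 2 (0.63 log units; beyond the scatter), compound 4 is expected to weaken by about a 3.4-fold higher number from compound 3 to compound 4 (0.53 log units; beyond the scatter), so an estimate of 300000 nM is made.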

Compound 4, half-maximal inhibitory concentration: > 128000 nM
Compound 4 was reported as a limit; the forecaster's own chance of this, stated with the estimate: 75%; the middle value is on the limit's open side.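

In this assay compound 4 gives > 128000 nM, a limit of the assay and not a number, so the new step, an at least 1.4-fold higher number from compound 3 to compound 4 (0.15 log units; that floor lies within the scatter), is a floor only. Loss of activity on removing the propyl is thus beyond the scatter on the core of compound 1 but not shown on the core of compound 3, though a loss of similar or larger size there is not excluded: the same change on two cores in this assay, an at least 4.3-fold higher number (0.63 log units; beyond the scatter) from compound 1 to compound 2 and an at least 1.4-fold higher number (0.15 log units; that floor lies within the scatter) from compound 3 to compound 4; the limit leaves it open whether they differ Neither shortened compound yields a number, so the full size of the change stays unknown on both cores: the limit of > 128000 nM in this assay, at which 2 of the 4 values shown sit.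

Still open, from the compounds shown here alone, is how a longer chain would read on either core in this assay. Also open is how the two cores compare on a single chain, as no pair shown differs in the core alone.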